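Trimethoxyphenyl triazoles: removing a chloro substituent

This account rests on a few compounds, and the source may have more. Where it says the series, first, only, none or still open, it means among the compounds named here.

Working notes on a set of triazoles carrying a trimethoxyphenyl group, read in a functional assay on A549 cells (Homo sapiens) for antiproliferative activity, read by MTT assay, with a stated time of 72 h; a higher number here means a weaker inhibitor, a lower number a stronger inhibitor.

Compound 1 `COc1cc(-n2ncnc2-c2ccc(Cl)cc2)cc(OC)c1OC` carries a 4-chlorophenyl group. In this assay compound 1 gives > 10000 nM, which is a limit of the assay and not a number. Compound 2 `COc1cc(-n2ncnc2-c2ccc(Cl)c(Cl)c2)cc(OC)c1OC` carries a 3,4-dichlorophenyl group; in this assay compound 2 gives > 10000 nM, again a limit rather than a number. Compound 3 `COc1cc(-c2ncnn2-c2ccc(Cl)cc2)cc(OC)c1OC` places the two aryl groups on the triazole core in a different arrangement; in this assay compound 3 gives > 10000 nM, also a limit. How the core of compound 3 differs from the core of compound 2 is not broken down here.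

One measured step exists: hydrogen in place of chloro on an aromatic carbon, and in this assay it reads a step that the two limits leave unreadable from compound 2 to compound 1. Its size cannot be read because the limit of > 10000 nM in this assay, at which 3 of the 3 values shown sit, places both ends at the limit.

Compound 4 `COc1cc(-c2ncnn2-c2ccccc2)cc(OC)c1OC` is not yet measured. It differs from compound 3 by hydrogen in place of chloro on an aromatic carbon. This is the same kind of change as from compound 2 to compound 1, but not the same: in compound 2 the chloro that leaves sits ortho to a chloro group and meta to a large group, whereas in compound 3 it sits para to a large group.

With all three measured values at the limit, the step is expected to be a step that the limit leaves unreadable from compound 3 to compound 4, resting only on compound 3 at > 10000 nM and on the unreadable step from compound 2 to compound 1. Compound 4 is therefore expected to give about 20000 nM in this assay, estimated between 8000 nM and 60000 nM, most likely reported as a limit.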

Compound 4, half-maximal inhibitory concentration: > 10000 nM
Compound 4 gave a limit, no number (the forecaster's own chance of this, stated with the estimate: 90%); the middle value is on the limit's open side.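

In this assay compound 4 gives > 10000 nM, which is a limit of the assay and not a number. No size can be read for the change from compound 3 to compound 4, because both compounds stand at the same limit: the limit of > 10000 nM in this assay, at which 4 of the 4 values shown sit.

The compounds shown leave open whether hydrogen in place of chloro alters antiproliferative activity at all, since none of them gives a readable value.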